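A few compounds are considered here, and "the series" means these few. Any claim that something is new, unique, unknown or untested is made for them only; others in the source may bear on it.

Compound 1 `CC(=O)OCC(CCn1cc(C#Cc2ccc(Br)cc2)c(=O)n(C(=O)c2ccccc2)c1=O)COC(C)=O` and compound 2 `CCCCCC#Cc1cn(CCC(COC(C)=O)COC(C)=O)c(=O)n(C(=O)c2ccccc2)c1=O` have been measured. In a functional assay on HeLa cells (Homo sapiens) for antiproliferative activity, read by MTT assay, with a stated time of 72 h (on this read-out higher numbers stand for weaker inhibition and lower numbers for stronger inhibition), compound 1 gives 47200 nM, and compound 2 gives 53700 nM; compound 1 thus holds the lowest of the two numbers, with compound 2 within the scatter of it. Compound 3 `CCCCCCCCC#Cc1cn(CCC(COC(C)=O)COC(C)=O)c(=O)n(C(=O)c2ccccc2)c1=O` has not been measured. It differs from compound 1 in octyl in place of 4-bromophenyl on a triple-bonded carbon. For the measured compounds named here, the one step that bears on this change is a 1.1-fold higher number from compound 1 to compound 2 (0.06 log units; within the scatter), which exchanged the same group for a shorter chain on the same carbon. Compound 3 is therefore expected to show no step beyond the scatter, a 1.1-fold higher number from compound 1 to compound 3 (0.03 log units; within the scatter). The estimate for compound 3 is 50000 nM, with a range from 25000 nM to 100000 nM.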

Compound 3, half-maximal inhibitory concentration: 32400 nM
Compound 3: the middle estimate sits 1.5-fold (0.19 log units) above what was measured; measured number inside the range.
By their numbers in this assay, from the lowest: compounds 3, 1 and 2 (each within the scatter of the next).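

In this assay, octyl on the triple-bonded carbon in place of 4-bromophenyl gives a step within the scatter (a 1.5-fold lower number from compound 1 to compound 3 (0.16 log units; within the scatter)), as the pentyl chain did. The lengthened chain adds a comparison between two chains (a 1.7-fold lower number from compound 2 to compound 3 (0.22 log units; within the scatter)), so across these compounds neither ring nor chain length on this carbon gives a step beyond the scatter. No evidence is available to explain this.

Still open, going by these compounds, is whether a longer chain, or a chain carrying an amine or a carboxylic acid, on this carbon would give a step beyond the scatter.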